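Adding a second chloro to the benzyl arm of compound 3

This account rests on a few compounds, and the source may have more. Where it says the series, first, only, none or still open, it means among the compounds named here.

Three analogues sharing one core have been measured in a functional assay on MCF7 cells (Homo sapiens) for antiproliferative activity, read by MTT assay, with a stated time of 48 h, in the presence of a further agent that is not named here; a higher number here means a weaker inhibitor of growth, a lower number a stronger inhibitor of growth. Compound 1 `Cc1ccc(-c2nn(-c3ccccc3)cc2C(=O)NOCc2ccc(Cl)cc2Cl)cc1` gives 2310 nM. Compound 2 `O=C(NOCc1ccccc1F)c1cn(-c2ccccc2)nc1-c1ccc(Cl)cc1` gives 15100 nM, and compound 3 `O=C(NOCc1ccccc1Cl)c1cn(-c2ccccc2)nc1-c1ccc(Cl)cc1` gives 16100 nM. Compound 3 thus holds the highest of the three numbers, sitting within the scatter of compound 2 and well apart from compound 1.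

The step to compound 4 `O=C(NOCc1ccc(Cl)cc1Cl)c1cn(-c2ccccc2)nc1-c1ccc(Cl)cc1` is chloro in place of hydrogen on an aromatic carbon. Among the compounds with values here, only one measured step is available, a 1.1-fold higher number from compound 2 to compound 3 (0.03 log units; within the scatter), and it concerns the exchange of one halogen for another at a different carbon, so it bears on the present change only loosely. Within the data shown here, compound 1, which carries the same 2,4-dichlorobenzyl group as compound 4 but differs from it elsewhere, gives a number far lower than compound 3; no single step separates compound 1 from compound 3, so it can only hint at the direction. On that basis compound 4 is expected to reach a lower number than compound 3, with the estimated step of a 3.2-fold lower number from compound 3 to compound 4 (0.51 log units; beyond the scatter). Compound 4 is estimated at 5000 nM, with a range from 1500 nM to 16000 nM in this assay.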

Compound 4, concentration for 50% growth inhibition: 16200 nM
Compound 4: the middle estimate sits 3.2-fold (0.51 log units) below what was measured; measured number above the stated range.
By their numbers in this assay, from the lowest: compound 1; then compounds 2, 3 and 4 (each within the scatter of the next).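

In this assay, chloro para to a large group and meta to a chloro group, which turns the 2-chlorobenzyl arm into the 2,4-dichlorobenzyl arm, gives a 1.0-fold higher number from compound 3 to compound 4 (0.00 log units; within the scatter), and the comparison with the fluoro analogue gives a 1.1-fold higher number from compound 2 to compound 4 (0.03 log units; within the scatter), so compounds 2, 3 and 4 cannot be told apart in this series, whichever of these three benzyl arms they carry. The 2,4-dichlorobenzyl arm therefore does not by itself account for the low number of compound 1: with that arm held constant, the one remaining difference gives a 7.0-fold higher number from compound 1 to compound 4 (0.85 log units; beyond the scatter), a step beyond the scatter that places the difference at this other site. Nothing available here explains either the flat result at the benzyl arm or the step at the other site.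

As far as these compounds go, it remains open whether a methoxy group or an amine at the carbon para to the large group would separate from compound 3 when the partner ring carries chloro. From the compounds shown here alone, it is also open whether chloro in place of methyl would give a step of similar size with the 2-chlorobenzyl or 2-fluorobenzyl arm.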